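Swapping the aryl group on the amide nitrogen

The source may hold more compounds than are shown below. What is called first, only, known or untested is meant among the compounds shown, and "the series" means these compounds.

Of the compounds shown here, two have been measured so far, and they differ only in the aromatic group attached to the amide nitrogen. Compound 1 `CCc1cccc(NC(=O)CN2CCC(c3cccc[n+]3[O-])CC2)c1` gives 95 nM in a functional assay on HEK293 cells for agonist activity at D(4) dopamine receptor (Homo sapiens), read by FLIPR; a higher number here means that more compound is needed for the effect, a lower number that less compound is needed. Compound 2 `Cc1cc(Br)ccc1NC(=O)CN1CCC(c2cccc[n+]2[O-])CC1` gives 66 nM in this assay, the lower of the two numbers, though the step of a 1.4-fold lower number from compound 1 to compound 2 (0.16 log units; within the scatter) stays within the scatter, so the two cannot be ranked against each other.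

Compound 3 `Cc1cccc(C)c1NC(=O)CN1CCC(c2cccc[n+]2[O-])CC1` has not yet been measured. It differs from compound 2 in one place: 2,6-dimethylphenyl in place of 4-bromo-2-methylphenyl on an amide-type nitrogen. For the measured compounds named here, the only measured step that speaks to this kind of change is a 1.4-fold lower number from compound 1 to compound 2 (0.16 log units; within the scatter), where one aryl group replaced another on the same nitrogen and the number barely moved. That single step cannot show whether a further aryl swap will matter, so no change beyond the scatter is expected. Allowing for a modest rise, the expected step is a 1.8-fold higher number from compound 2 to compound 3 (0.26 log units; within the scatter). Compound 3 is therefore estimated to give 120 nM in this assay, with a likely range from 40 nM to 400 nM.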

Compound 3, half-maximal effective concentration: 346 nM
Compound 3: the middle estimate sits 2.9-fold (0.46 log units) below what was measured; the range from low to high includes it.
By their numbers in this assay, from the lowest: compounds 2 and 1 (each within the scatter of the next); then compound 3.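

In this assay, placing 2,6-dimethylphenyl on the amide-type nitrogen gives a 5.2-fold higher number from compound 2 to compound 3 (0.72 log units; beyond the scatter) and a 3.6-fold higher number from compound 1 to compound 3 (0.56 log units; beyond the scatter), so unlike the earlier swap, this change moves the number beyond the scatter and the aryl group here cannot be exchanged freely. The change is not visible in the simple counts: 4-bromo-2-methylphenyl and 2,6-dimethylphenyl both have 8 heavy atoms, one six-membered aromatic ring of carbon only, 0 hydrogen-bond donors, 0 hydrogen-bond acceptors and no net charge, so a step of this size can occur with all of those held equal. Nothing measured here accounts for the rise in the number.

The compounds shown do not separate the loss of the bromine from the gain of a methyl group, as both occur together in the single change from compound 2 to compound 3. They also leave open how the number would respond to a plain phenyl group, or to an aryl group carrying an amine or a carboxylic acid, on the same nitrogen.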